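From cyclopentyl to 3,3,3-trifluoropropyl on the shared core

This account rests on a few compounds, and the source may have more. Where it says the series, first, only, none or still open, it means among the compounds named here.

Of the compounds shown here, three have been read in an ADME assay on microsomes from liver (Homo sapiens) for metabolic stability, with a stated time of 30 min, tested at 1 uM; on this read-out lower numbers stand for a less stable compound and higher numbers for a more stable compound: compound 1 (`CC[C@@H]1C(=O)N(C)c2cnc(-c3cn[nH]c3-c3ccc(F)cc3F)nc2N1c1cnn(C)c1`) gives 48%, compound 2 (`CC[C@@H]1C(=O)N(C)c2cnc(-n3ccnc3-c3ccccc3)nc2N1C1CCCC1`) gives 0% and compound 3 (`CC[C@@H]1C(=O)N(C)c2cnc(-n3ccnc3-c3ccc(F)cc3)nc2N1C1COC1`) gives 74%. Compound 2 is the lowest of the three, and compound 1 and compound 3 both stand above it beyond the scatter. No two of these compounds differ in only one place, so the data hold no direct measure of any single change.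

Compound 4 (`CC[C@@H]1C(=O)N(C)c2cnc(-n3ccnc3-c3ccccc3)nc2N1CCC(F)(F)F`) departs from compound 2 in one place: 3,3,3-trifluoropropyl in place of cyclopentyl on a nitrogen on an aromatic ring in a ring. Here 3,3,3-trifluoropropyl takes the place of cyclopentyl on a nitrogen on an aromatic ring in a ring, next to the ring atom that bears an ethyl group.

In this assay a moderate upward step beyond the scatter is expected. Compound 2 at 0% leaves no room for a downward step. Compound 1 at 48% and compound 3 at 74% carry no cyclopentyl, but they differ from compound 2 elsewhere too, so this support is weak and the expected range stays wide. The expected change is a number 30 percentage points higher from compound 2 to compound 4 (beyond the scatter). The estimated value for compound 4 is 30%, with an expected range of 5% to 60%.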

Compound 4, percent of the compound remaining: 0%
The estimate for compound 4 lay 30 percentage points above the measured number; the measured number lies below the stated range.
By their numbers in this assay, from the lowest: compounds 2 and 4 (each within the scatter of the next); then compound 1; then compound 3.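

The one-place change at this nitrogen reads in this assay as no change at the digits printed from compound 2 to compound 4 (within the scatter), so on this core 3,3,3-trifluoropropyl in place of cyclopentyl gives no measurable gain in the percent-remaining read-out. Within the data shown here, compound 2 and compound 4 both sit at the very bottom of that read-out, so the step shows only that neither compound reaches a measurable number, and any difference between them that lies under this floor stays unseen. Losing the cyclopentyl ring is therefore not enough by itself to give a measurable number while the rest of compound 2 stays in place, and nothing available accounts for this result.

Still open, on these data alone, is whether any group on this nitrogen can lift the number while the phenyl on the imidazole side of compound 2 stays unchanged, for instance a hydroxyethyl chain, a morpholine-bearing chain or a simple amine. Also open, as far as these compounds go, is how much the same exchange of cyclopentyl for 3,3,3-trifluoropropyl would move the number on a compound that starts well above the floor, where a step in either direction could be read.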